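A few compounds are considered here, and "the series" means these few. Any claim that something is new, unique, unknown or untested is made for them only; others in the source may bear on it.

Three compounds have been measured in a functional assay on HT-29 cells (Homo sapiens) for antiproliferative activity, read by MTT assay, with a stated time of 48 h; on this read-out lower numbers stand for stronger inhibition and higher numbers for weaker inhibition:

Compound 1, `COc1cc(/C=N/c2c(C#N)ncn2-c2ccc(F)cc2)cc(OC)c1OC`, gives 13700 nM.
Compound 2, `COc1ccc(OC)c(/C=N/c2c(C#N)ncn2-c2ccc(F)cc2)c1`, gives 16300 nM.
Compound 3, `N#Cc1ncn(-c2ccc(F)cc2)c1/N=C/c1ccc([N+](=O)[O-])cc1`, gives 15900 nM.

All three share the same core and differ only in the aromatic ring attached through the imine. Compound 3 carries a nitro group there and gives the second highest of the three numbers. Its nearest neighbour is compound 2, and its furthest is compound 1; both gaps lie within the usual scatter of this assay, so the three values cannot be told apart, and none of the three compounds can be called the strongest or the weakest.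

Compound 4, `N#Cc1ncn(-c2ccc(F)cc2)c1/N=C/c1ccc(O)cc1`, has not been measured. It differs from compound 3 in one place: hydroxy in place of nitro on an aromatic carbon. Going by the values given here, no measured pair shows what this kind of exchange does here, so the expectation rests only on the three values shown, which all sit close together. On that basis the step in this assay from compound 3 to compound 4 is expected to be small, in no particular direction, and to stay within the scatter: a 1.1-fold lower number from compound 3 to compound 4 (0.03 log units; within the scatter). Compound 4 is therefore estimated at 15000 nM, with a range from 6000 nM to 40000 nM.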

Compound 4, half-maximal inhibitory concentration: 20400 nM
Compound 4: middle estimate off by 1.4-fold (0.13 log units), on the low side; measured number inside the range.
By their numbers in this assay, from the lowest: compounds 1, 3, 2 and 4 (each within the scatter of the next).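

In this assay, the first exchange read at this place on the aromatic ring, hydroxy in place of nitro, para to a large group, amounts to a 1.3-fold higher number from compound 3 to compound 4 (0.11 log units; within the scatter), a step that stays within the usual scatter. The exchange is not a slight one on paper: three heavy atoms with no hydrogen-bond donor leave, and a single oxygen with one hydrogen-bond donor enters, yet the two compounds cannot be told apart, so for this one pair the read-out does not register the swap. This is a single pair, it supports no general rule about the position, and nothing available accounts for the step or for its small size.

The compounds shown leave open whether a different group at this same place, such as an amine or a carboxylic acid, would give a step beyond the scatter. They also leave open what an exchange elsewhere on the shared core would do, for example an amide in place of the nitrile, since every compound here keeps that group unchanged.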